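The compounds below may be only part of what the source reports. "The series", "measured", "known", "first", "only" and "open" are said of these compounds alone.

Compound 1 `NC(=O)[C@H]1OC(n2cnc3c(N)ncnc32)[C@H](O)[C@@H]1O` carries a plain carbamoyl group on its sugar ring. Going by the values given here, in an assay on cell membranes for binding affinity to 2-oxoglutarate receptor 1 (Rattus norvegicus), read by radioligand binding (on this read-out lower numbers stand for stronger inhibition and higher numbers for weaker inhibition), compound 1 gives 64 nM, the highest of the three numbers measured so far. Compound 3 `C[C@H]1CC[C@@H](NC(=O)[C@H]2O[C@@H](n3cnc4c(N)ncnc43)[C@H](O)[C@@H]2O)CC1` gives 55.6 nM in this assay, a value within the usual scatter of that of compound 1. Among the compounds with values here, compound 2 `Nc1ncnc2c1ncn2C1O[C@H](C(=O)NC2CCCCCCC2)[C@@H](O)[C@H]1O` gives 23 nM in this assay; the one step that alters the amide-type nitrogen is a 2.8-fold lower number from compound 1 to compound 2 (0.44 log units; beyond the scatter), a modest improvement.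

Compound 4 `Nc1ncnc2c1ncn2C1O[C@H](C(=O)NO)[C@@H](O)[C@H]1O` has not yet been measured. Its difference from compound 1 is hydroxy in place of hydrogen on an amide-type nitrogen. Within the data shown here, only the step from compound 1 to compound 2 bears on this change, since it alone touches the same nitrogen, but a small hydroxy is far removed in size from a cyclooctyl, so its outcome cannot be carried over directly. Compound 4 is therefore expected to give about 60 nM in this assay, within a range of 25 nM to 150 nM. The expected step, a 1.1-fold lower number from compound 1 to compound 4 (0.03 log units; within the scatter), would lie within the scatter.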

Compound 4, inhibition constant: 41 nM
Estimate against measurement, compound 4: 1.5-fold (0.17 log units) above; the measured number falls inside the stated range.
By their numbers in this assay, from the lowest: compounds 2, 4, 3 and 1 (each within the scatter of the next, the first and the last beyond it).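

In this assay the hydroxy group on the amide-type nitrogen gives a 1.6-fold lower number from compound 1 to compound 4 (0.19 log units; within the scatter) and a 1.8-fold higher number from compound 2 to compound 4 (0.25 log units; within the scatter) so compound 4 cannot be told apart from either compound, although compound 1 and compound 2 can be told apart from each other. This shows that a single oxygen atom can be placed on this nitrogen without a change that rises above the scatter, but compound 4 cannot show whether hydroxy behaves more like hydrogen or more like cyclooctyl. Nothing available explains this result.

Still open, going by these compounds, is whether a methoxy group or an amino group on the same nitrogen would give a similar number. On these data alone, it is also open whether a short chain such as ethyl would read closer to compound 1 or to compound 2.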